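Removing one hydroxy from a catechol-bearing thione

The source may report more compounds than this note shows. Statements on the series, on what has been measured and on what is new or still open speak of the compounds shown alone.

Measured so far:
Compound 1 `CCOC(=O)C1=C(C)NC(=S)NC1c1ccc(O)c(O)c1`: 33.7 ug/mL
Compound 2 `CCOC(=O)C1=C(C)NC(=S)NC1c1cc(OC)c(O)c(OC)c1`: 28.2 ug/mL

In a functional assay on HT-29 cells (Homo sapiens) for inhibition, read by sulforhodamine B assay, with a stated time of 48 h (a higher number here means a weaker inhibitor of growth, a lower number a stronger inhibitor of growth), compound 1 gives 33.7 ug/mL, the higher of the two numbers in hand. Among the compounds with values here, its only neighbour on this scale is compound 2, which gives 28.2 ug/mL in this assay; the two values lie within the scatter of each other, so nothing can be said about an order between them.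

Compound 3 `CCOC(=O)C1=C(C)NC(=S)NC1c1ccc(O)cc1` has not yet been measured in this assay. It differs from compound 1 by hydrogen in place of hydroxy on an aromatic carbon, at an aromatic carbon of a six-membered aromatic ring of carbon only. Within the data shown here, no pair of measured compounds shows the effect of this change, so there is no measured step to lean on.

Among the measured compounds shown here, with only two closely matched values to go by, the step from compound 1 to compound 3 in this assay is expected to be small, probably not beyond the scatter, with a slight lean towards a higher number. Compound 3 is therefore estimated to give 42 ug/mL in this assay, within a range of 16 ug/mL to 110 ug/mL, which corresponds to an expected step of a 1.2-fold higher number from compound 1 to compound 3 (0.10 log units; within the scatter).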

Compound 3, concentration for 50% growth inhibition: > 250 ug/mL
Compound 3: only a limit was reported (the forecaster's own chance of this, stated with the estimate: 15%); middle value at least 5.9-fold (0.77 log units) from the limit.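

For compound 3 the reading in this assay is a limit, > 250 ug/mL, and not a number. Hydrogen in place of hydroxy on this aromatic carbon, ortho to a hydroxy group and meta to a large group, gives an at least 7.4-fold higher number from compound 1 to compound 3 (0.87 log units; beyond the scatter). This is the first step in hand that changes one place only, and it shows that the series is sensitive to this change at this position, which the two close values of compound 1 and compound 2 could not reveal, and the size of the step is only a lower bound: the limit of > 250 ug/mL in this assay, at which 1 of the 3 values shown sits.

On these data alone, what stays open is whether the hydroxy itself is needed here, or whether another group on the same aromatic carbon, such as an amine, a fluorine or a methyl, would hold the value of compound 1. Also open, as far as these compounds go, is what the hydroxy that remains in compound 3 contributes, and how far the true value of compound 3 lies from its limit.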